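The source may report more compounds than this note shows. Statements on the series, on what has been measured and on what is new or still open speak of the compounds shown alone.

Measured compounds:
- compound 1 `C=C1C[C@H](CO)OC1=O`: 27200 nM
- compound 2 `C=C1C[C@H]([C@@H](O)CCC)OC1=O`: 16900 nM

Both compounds share the same core and differ only at the carbon bearing the hydroxyl. In a functional assay on L1210 cells (Mus musculus) for cytotoxicity (a higher number here means a weaker inhibitor, a lower number a stronger inhibitor), compound 1 gives 27200 nM; compound 2 gives 16900 nM. Compound 2 has the lowest of the two numbers, but the step of a 1.6-fold lower number from compound 1 to compound 2 (0.21 log units; within the scatter) lies within the scatter, so no order between compound 1 and compound 2 can be read from these values.

Compound 3 `C=C1C[C@H]([C@H](C)O)OC1=O` has not yet been measured. It differs from compound 2 by hydrogen in place of ethyl on a saturated chain carbon, two bonds along the chain from an oxygen on a saturated carbon and a saturated ring carbon. Compound 3 therefore sits between compound 1 and compound 2 in the length of that chain. Among the measured compounds shown here, the only step that bears on this change is a 1.6-fold lower number from compound 1 to compound 2 (0.21 log units; within the scatter), which shows that adding the full propyl chain made no difference beyond the scatter. Shortening the chain by ethyl is expected to do the same, giving a step of a 1.2-fold higher number from compound 2 to compound 3 (0.07 log units; within the scatter) of no real size in this assay. For compound 3 the expected value in this assay is 20000 nM, with a range from 8000 nM to 50000 nM.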

Compound 3, half-maximal inhibitory concentration: 17300 nM
Estimate against measurement, compound 3: 1.2-fold (0.06 log units) above; the range from low to high includes it.
By their numbers in this assay, from the lowest: compounds 2, 3 and 1 (each within the scatter of the next).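

Working from this assay, cutting propyl to methyl on the saturated chain carbon gives a 1.0-fold higher number from compound 2 to compound 3 (0.01 log units; within the scatter), and setting methyl in place of hydrogen on the saturated chain carbon bound to an oxygen gives a 1.6-fold lower number from compound 1 to compound 3 (0.20 log units; within the scatter), so both new steps lie within the scatter. The earlier pair covered only hydrogen and propyl at this carbon; with methyl as a third group, a chain of intermediate length also gives no separation, and these three compounds cannot be ordered by their numbers, so no dependence on chain length can be read at this position within the range from hydrogen to propyl. No supporting data bear on why this position gives so flat a reading in these three compounds.

As far as these compounds go, whether a chain longer than propyl, a phenyl group or a carboxylic acid on this carbon would give a step beyond the scatter remains open. Also open is whether an amine in place of the hydroxyl, or a change elsewhere on the shared core, would move the number at all, since every difference shown here lies at this one carbon.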